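Series notes: ester in place of aryl ketone

The source may hold more compounds than are shown below. What is called first, only, known or untested is meant among the compounds shown, and "the series" means these compounds.

In a functional assay on OE19 cells (Homo sapiens) for cytotoxicity, read by MTT assay, with a stated time of 48 h (on this read-out lower numbers stand for stronger inhibition and higher numbers for weaker inhibition), compound 3 `CC1(C)S[C@@H]2/C(=C\C(=O)c3ccc(F)cc3)C(=O)N2[C@H]1C(=O)OC(c1ccccc1)c1ccccc1` gives 12100 nM, the lowest of the three numbers recorded. Among the compounds with values here, compound 1 `CC1(C)S[C@@H]2/C(=C\C(=O)c3ccc([N+](=O)[O-])cc3)C(=O)N2[C@H]1C(=O)OC(c1ccccc1)c1ccccc1` gives 44100 nM; the one single-point step so far, a 3.6-fold lower number from compound 1 to compound 3 (0.56 log units; beyond the scatter), concerns only the aromatic substituent and does not bear on the change considered here. Within the data shown here, compound 2 `COC(=O)/C=C1\C[C@H]2SC(C)(C)[C@H](C(=O)OC(c3ccccc3)c3ccccc3)N2C1=O`, which also carries a methoxycarbonyl, gives 99700 nM; no step to compound 3 is counted for it, so its value only shows that the one methoxycarbonyl compound measured sits at the weak end. Compound 4 `COC(=O)/C=C1/C(=O)N2[C@@H]1SC(C)(C)[C@@H]2C(=O)OC(c1ccccc1)c1ccccc1` differs from compound 3 by methoxy in place of 4-fluorophenyl on a carbonyl carbon. Because compound 2 gives 99700 nM, a higher number is expected for compound 4, a 5.0-fold higher number from compound 3 to compound 4 (0.70 log units; beyond the scatter). Compound 4 is estimated at 60000 nM, within 20000 nM to 150000 nM.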

Compound 4, half-maximal inhibitory concentration: 20200 nM
Compound 4: middle estimate off by 3.0-fold (0.47 log units), on the high side, and the stated range covers the measured number.
By their numbers in this assay, from the lowest: compounds 3 and 4 (each within the scatter of the next); then compound 1; then compound 2.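

In this assay, the aromatic ring is not needed on this carbonyl carbon: methoxy in place of 4-fluorophenyl gives a 1.7-fold higher number from compound 3 to compound 4 (0.22 log units; within the scatter), so the two compounds cannot be separated. Methoxy in place of 4-nitrophenyl gives a 2.2-fold lower number from compound 1 to compound 4 (0.34 log units; beyond the scatter), so the outcome of this change depends on which aryl group leaves. Open, going by these compounds, is whether a hydroxyl, an amine or a longer chain on this carbonyl carbon would give a number like that of compound 4. No measurement available here explains either step.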